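Aryl swap at the chain end: compound 2 to compound 3

The source may hold more compounds than are shown below. What is called first, only, known or untested is meant among the compounds shown, and "the series" means these compounds.

compound 1 `COc1ccccc1/C=C/CCCOc1cc(/C=C\c2cc(OC)c(OC)c(OC)c2)ccc1OC` — > 400000 nM (a limit)
compound 2 `COc1cccc(/C=C/CCCOc2cc(/C=C\c3cc(OC)c(OC)c(OC)c3)ccc2OC)c1` — 39000 nM
compound 3 `COc1ccc(/C=C\c2cc(OC)c(OC)c(OC)c2)cc1OCCC/C=C/c1ccc(Cl)cc1` — not yet measured

In an ADME assay on HEK293 cells (Homo sapiens) for inhibition, read by MTT assay, with a stated time of 3 days (a lower number here means a stronger inhibitor, a higher number a weaker inhibitor), compound 1 gives only a limit, > 400000 nM. In this assay, going by the values given here, compound 2 gives 39000 nM; this is the only number so far. Compound 1 contributes only a limit. Among the compounds with values here, the one measured step is an at least 10-fold lower number from compound 1 to compound 2 (1.01 log units; beyond the scatter), a large change for an exchange of 2-methoxyphenyl against 3-methoxyphenyl on a double-bonded chain carbon bound to a double-bonded chain carbon.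

Compound 3 differs from compound 2 by 4-chlorophenyl in place of 3-methoxyphenyl on a double-bonded chain carbon bound to a double-bonded chain carbon. Within the data shown here, no measured step exchanges the substituent itself on that ring; the step from compound 1 to compound 2 shows only that this ring position matters, and it rests on one limit. The direction of the change to compound 3 therefore cannot be read from the data, and the expectation is for a 1.1-fold lower number from compound 2 to compound 3 (0.05 log units; within the scatter), not beyond the scatter, with a wide range either way. Compound 3 is thus estimated at 35000 nM, between 8000 nM and 150000 nM.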

Compound 3, half-maximal inhibitory concentration: 111000 nM
Compound 3: middle estimate off by 3.2-fold (0.50 log units), on the low side; the measured number falls inside the stated range.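

The exchange of 3-methoxyphenyl for 4-chlorophenyl on a double-bonded chain carbon bound to a double-bonded chain carbon joins two measured numbers in this assay, and it gives a 2.8-fold higher number from compound 2 to compound 3 (0.45 log units; beyond the scatter). The direction at this place can now be read for a pair without a limit: 3-methoxyphenyl gives the lower number of the two, by a modest margin. The remaining step, an at least 3.6-fold lower number from compound 1 to compound 3 (0.55 log units; beyond the scatter), puts 2-methoxyphenyl at the weak end of the three aryl groups, but compound 1 gives only a limit, and that step has no fixed size: the limit of > 400000 nM in this assay, at which 1 of the 3 values shown sits.

The gap between 3-methoxyphenyl and 4-chlorophenyl combines a change of group with a change of its ring position, and a 4-methoxyphenyl or a 3-chlorophenyl at this place would separate the two. Also open, from the compounds shown here alone, is how this place responds to a chain-end group of a different kind, such as a carboxylic acid or an amine on the aromatic ring.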